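The compounds below may be only part of what the source reports. "The series", "measured", "known", "first", "only" and "open" are said of these compounds alone.

Measured so far in an assay on isolated protein for inhibition of acyl-CoA desaturase 1 (Rattus norvegicus); on this read-out lower numbers stand for stronger inhibition and higher numbers for weaker inhibition:
- compound 1, `O=C(O)c1cccc(-c2ccc(N3CCC(Oc4ccccc4C(F)(F)F)CC3)nn2)c1`: 107 nM
- compound 2, `O=C(O)c1cncc(-c2ccc(N3CCC(Oc4ccccc4Br)CC3)nn2)c1`: 47 nM

Compound 2 gives the lower of the two numbers; the number for compound 1 lies higher, beyond the scatter. Compound 3, `O=C(O)c1cncc(-c2ccc(N3CCC(Oc4c(F)cc(F)cc4Br)CC3)nn2)c1`, differs from compound 2 in one place: 2-bromo-4,6-difluorophenyl in place of 2-bromophenyl on an oxygen on a saturated carbon. For the measured compounds named here, no measured step of this kind exists, so the size of the change is unknown here. The expectation is a step in this assay no larger than the scatter, leaning if anything towards a lower number. The expected step from compound 2 to compound 3 is a 1.2-fold lower number from compound 2 to compound 3 (0.09 log units; within the scatter). For compound 3 the estimate is 38 nM, in a range from 14 nM to 110 nM.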

Compound 3, half-maximal inhibitory concentration: > 20000 nM
Compound 3: a limit, no number (the forecaster's own chance of this, stated with the estimate: 3%); middle value at least 520-fold (2.72 log units) from the limit.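

In this assay, the aryl group on this oxygen proves far less forgiving than compounds 1 and 2 suggested: adding two fluorines to 2-bromophenyl gives an at least 420-fold higher number from compound 2 to compound 3 (2.62 log units; beyond the scatter). This single change, 2-bromo-4,6-difluorophenyl in place of 2-bromophenyl, is enough to take the series out of measurable range. The result for compound 3 is a limit of the assay and not a number, so the true size of the step stays unknown: the limit of > 20000 nM in this assay, at which 1 of the 3 values shown sits.

The cause of the loss remains open. Whether one fluorine alone accounts for it would need 2-bromo-4-fluorophenyl and 2-bromo-6-fluorophenyl on the same core.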